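Swapping the isopropyl for chloro on the outer ring

The source may hold more compounds than are shown below. What is called first, only, known or untested is meant among the compounds shown, and "the series" means these compounds.

Of the compounds shown here, three share one core and have been tested in a functional assay on the whole organism (stomach) for inhibition, with Rattus norvegicus as the target, at a dose of 80 mg/kg; a lower number here means less inhibition, a higher number more inhibition at the dose given (going by the name of the read-out). Compound 1 `CC(C)c1ccc(-c2cc(=O)c3cc(C(=O)O)ccc3o2)cc1` gives 19%. Compound 2 `CC(C)c1ccc(-c2oc3ccc(C(=O)O)cc3c(=O)c2O)cc1`, which carries an extra hydroxy, gives 24%, and the step of a number 5 percentage points higher from compound 1 to compound 2 (within the scatter) stays within the scatter. Compound 3 `COc1cc(-c2oc3ccc(C(=O)O)cc3c(=O)c2O)cc(OC)c1OC` gives 24%, so compound 2 and compound 3 stand level at the digits shown, together the highest of the three numbers, with compound 1 the furthest away by a small margin.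

Compound 4 `O=C(O)c1ccc2oc(-c3ccc(Cl)cc3)c(O)c(=O)c2c1` is the next to be measured. It differs from compound 2 in this way: chloro in place of isopropyl on an aromatic carbon. Among the measured compounds shown here, no measured step covers a change of this kind; the only measured step concerns a hydroxy, not the outer ring. What compound 2 and compound 3 show is that two quite different groups on that outer ring give the same inhibition, which gives no reason to expect a large move. The step of no change at the digits printed from compound 2 to compound 4 (within the scatter) is therefore expected to stay inside the scatter. For compound 4 the expected value is 24%, with a range from 10% to 40%.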

Compound 4, a percentage reported as inhibition, in the whole organism at one dose (the size of the read-out at that dose, not a potency): -19%
Estimate against measurement, compound 4: 43 percentage points above; the whole stated range lies above it.
By their numbers in this assay, from the lowest: compound 4; then compounds 1, 2 and 3 (each within the scatter of the next).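

The position para to a large group on the six-membered aromatic ring of carbon only is not indifferent to what it carries: in this assay, chloro in place of isopropyl gives a number 43 percentage points lower from compound 2 to compound 4 (beyond the scatter). Among the compounds shown here, this is the first step to lie beyond the scatter, and compound 4 at -19% gives a negative reading, not merely a smaller inhibition. For the compounds shown here, nothing available here bears on why this single change moves the number so far.

One swap cannot separate an effect of gaining chloro from an effect of losing isopropyl. On these data alone, how a methyl, a fluoro or an amine at this place would read remains open, and with it whether the negative reading is particular to chloro.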